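Removing a Chloro Group Across Two Related Cores

A few compounds are considered here, and "the series" means these few. Any claim that something is new, unique, unknown or untested is made for them only; others in the source may bear on it.

Compound 1 `Cc1cc(C)nc(SCc2cc(=O)c3cc(Cl)ccc3o2)n1` and compound 3 `Cc1cc(C)nc(SCc2cc(=O)c3ccccc3o2)n1` share one core, while compound 2 `Cc1cc(C)n2nc(SCc3cc(=O)c4cc(Cl)ccc4o3)nc2n1` and compound 4 `Cc1cc(C)n2nc(SCc3cc(=O)c4ccccc4o3)nc2n1` share another; the difference between the two cores is not broken down here. In a functional assay on HEp-2 cells (Homo sapiens) for cytotoxicity, read by MTT assay, with a stated time of 72 h (on this read-out lower numbers stand for stronger inhibition and higher numbers for weaker inhibition), compound 1 reaches only the assay limit, > 25000 nM. In this assay compound 3 likewise gives only a limit, > 25000 nM. In this assay compound 2 also stops at a limit, > 25000 nM. The change from compound 1 to compound 3, (hydrogen in place of chloro on an aromatic carbon), yields a step that the two limits leave unreadable from compound 1 to compound 3. The same change, (hydrogen in place of chloro on an aromatic carbon), leads from compound 2 to compound 4. Since (the limit of > 25000 nM in this assay, at which 3 of the 3 values shown sit), compound 4 is expected to remain at the limit as well, and its estimated value in this assay is 40000 nM. The step this expectation implies is a step that the limit leaves unreadable from compound 2 to compound 4.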

Compound 4, half-maximal inhibitory concentration: > 25000 nM
Compound 4 gave a limit, no number; the forecaster's own chance of this, stated with the estimate: 85%; the middle value lies beyond the limit too.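

Compound 2 and compound 4 each give only a limit in this assay, so no step can be read between them: the limit of > 25000 nM in this assay, at which 4 of the 4 values shown sit.

The compounds shown leave open whether hydrogen in place of chloro changes the read-out on either core.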